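Lengthening the chain on the core nitrogen of compound 1

The source may report more compounds than this note shows. Statements on the series, on what has been measured and on what is new or still open speak of the compounds shown alone.

Compound 1 `CCCOCCn1c(N2CCN(C)CC2)nc2ccccc21` carries a 2-propoxyethyl group on an aromatic nitrogen of the shared core, and in a functional assay on ileum for inhibition of histamine H1 receptor (Cavia porcellus) (a higher number here means a weaker inhibitor, a lower number a stronger inhibitor), compound 1 gives 20 nM, the lowest of the two numbers reported. Compound 2 `CN1CCN(c2nc3ccccc3[nH]2)CC1`, bearing only hydrogen at that position, reaches no number in this assay: for compound 2 the result is the limit > 3000 nM. Compound 3 `CCCC(C)n1c(N2CCN(C)CC2)nc2ccccc21`, with a 1-methylbutyl group there, gives 1400 nM in this assay. The two changes away from compound 1 are both large: an at least 150-fold higher number from compound 1 to compound 2 (2.17 log units; beyond the scatter) and a 70-fold higher number from compound 1 to compound 3 (1.85 log units; beyond the scatter), while an at least 2.1-fold lower number from compound 2 to compound 3 (0.33 log units; beyond the scatter).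

Compound 4 `CCCCCCCCCCn1c(N2CCN(C)CC2)nc2ccccc21` differs from compound 1 as follows: octyl in place of propoxy on a saturated chain carbon, two bonds along the chain from an aromatic nitrogen. The ether oxygen of compound 1 thus goes, and a long plain chain remains. Among the compounds with values here, the nearest precedent is compound 3, where a plain alkyl chain in place of 2-propoxyethyl brought a 70-fold higher number from compound 1 to compound 3 (1.85 log units; beyond the scatter) in this assay. A weakening of similar order is therefore expected, with the longer chain adding uncertainty, so the step is estimated as a 30-fold higher number from compound 1 to compound 4 (1.48 log units; beyond the scatter). Compound 4 is expected to give about 600 nM in this assay, within a range from 100 nM to 4000 nM.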

Compound 4, half-maximal inhibitory concentration: 4200 nM
For compound 4 the middle estimate is 7.0-fold (0.85 log units) below the measured one; the whole stated range lies below it.
By their numbers in this assay, from the lowest: compound 1; then compound 3; then compound 4.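

Swapping propoxy for octyl at this saturated chain carbon, two bonds along the chain from an aromatic nitrogen, gives a 210-fold higher number from compound 1 to compound 4 (2.32 log units; beyond the scatter) in this assay, so the low number of compound 1 does not survive this long plain chain. Compound 3 had replaced the whole 2-propoxyethyl group with a branched chain, whereas compound 4 leaves the chain unbranched and changes it only beyond this carbon, which shows that the change there alone is enough for a large loss. For compound 2, with hydrogen on the aromatic nitrogen, the result is a limit and not a number, so compound 4 cannot be ordered against it: the limit of > 3000 nM in this assay, at which 1 of the 4 values shown sits.

The step removes propoxy, with its one hydrogen-bond acceptor, and brings in octyl, with its 8 heavy atoms, so the compounds shown do not separate the loss of the ether oxygen from the added length. As far as these compounds go, it remains open whether a shorter plain chain such as propyl, or a hydroxyl group or an amine at the end of the chain, would stay closer to compound 1.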